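Swapping the para chloro for a hydroxypentyl chain

The source may report more compounds than this note shows. Statements on the series, on what has been measured and on what is new or still open speak of the compounds shown alone.

Compound 3 `Clc1ccc(-c2nc(-c3ccc4nc[nH]c4c3)no2)cc1` sits second highest of the three values in a physicochemical assay for acid dissociation, using potentiometric titration: compound 3 gives 3.77, compound 1 `FC(F)(F)c1ccccc1-c1nc(-c2ccc3nc[nH]c3c2)no1` gives 4, and compound 2 `Brc1ccc(-c2nc(-c3ccc4nc[nH]c4c3)no2)cc1` gives 3.25. Compound 4 `OCCCCCc1ccc(-c2nc(-c3ccc4nc[nH]c4c3)no2)cc1` differs from compound 3 by 5-hydroxypentyl in place of chloro on an aromatic carbon. For the measured compounds named here, only one measured step touches the same aromatic carbon: a number 0.52 log units higher from compound 2 to compound 3 (beyond the scatter). Going by the values given here, no measured pair exchanges a halogen for a hydroxyalkyl chain, so the direction rests on that single step at the same position. A modest upward step is therefore expected for this assay, roughly a number 0.33 log units higher from compound 3 to compound 4 (beyond the scatter). Compound 4 is estimated to give 4.1, with a likely range from 3.6 to 4.6.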

Compound 4, acid dissociation constant: 4.25
Estimate against measurement, compound 4: 0.15 log units below; the range from low to high includes it.
By their numbers in this assay, from the lowest: compound 2; then compounds 3, 1 and 4 (each within the scatter of the next, the first and the last beyond it).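

At this aromatic carbon, where only the bromo and chloro compounds had been compared, a 5-hydroxypentyl chain moves the reading in this assay further in the same upward direction: the step is a number 0.48 log units higher from compound 3 to compound 4 (beyond the scatter) and the wider step is a number 1.00 log units higher from compound 2 to compound 4 (beyond the scatter). The position therefore tolerates a change from a single halogen atom to a chain without a return toward the lower number of compound 2. The compounds shown leave open whether a plain pentyl chain, a shorter hydroxyalkyl chain or a chain ending in an amine or a carboxylic acid would read alike. No measurement at hand accounts for these differences.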